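The source may hold more compounds than are shown below. What is called first, only, known or untested is meant among the compounds shown, and "the series" means these compounds.

Compound 1 `CC(=O)O[C@@H]1OC(=O)[C@](C)(C(C)=O)[C@@H]1C`, compound 2 `CC(=O)O[C@@H]1OC(=O)[C@@](C(C)=O)(C2SCCCS2)[C@@H]1C` and compound 3 `CC(=O)O[C@@H]1OC(=O)[C@](O)(C(C)=O)[C@@H]1C` share one core and differ at a single saturated ring carbon. In a functional assay on B16 cells (Mus musculus) for cytotoxicity, read by MTT assay (a higher number here means a weaker inhibitor, a lower number a stronger inhibitor), compound 1 gives 4000 nM. Compound 2 reaches only a limit of this assay, > 50000 nM, so where compound 2 stands is known to one side only. The one measured step, an at least 12-fold higher number from compound 1 to compound 2 (1.09 log units; beyond the scatter), ends at that limit (the limit of > 50000 nM in this assay, at which 1 of the 2 values shown sits), so its true size may be even greater than shown. The change to compound 3 is one oxygen atom in place of a group of 6 heavy atoms (4 carbon, 2 sulfur; one six-membered non-aromatic ring with 2 hetero atoms), on a saturated ring carbon. Among the measured compounds shown here, only that single measured step bears on it: placing the six-membered ring with two sulfur atoms at this carbon went with a large rise in the number, and taking it away again, leaving a hydroxy group of one oxygen atom, is expected to undo much of that rise. Compound 3 is therefore expected to sit closer to compound 1 than to compound 2, and the step of an at least 8.3-fold lower number from compound 2 to compound 3 (0.92 log units; beyond the scatter) is expected to be a clear fall in the number. Compound 3 is estimated at 6000 nM, within a range from 1500 nM to 40000 nM.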

Compound 3, half-maximal inhibitory concentration: > 50000 nM
Compound 3 ended at the assay's limit; the forecaster's own chance of this, stated with the estimate: 25%; at least 8.3-fold (0.92 log units) between middle value and limit.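

In this assay compound 3 gives > 50000 nM, which is a limit and not a number. Among the compounds shown here, the new information at this saturated ring carbon lies in the comparison with the methyl compound: hydroxy in place of methyl goes with an at least 12-fold higher number from compound 1 to compound 3 (1.09 log units; beyond the scatter), so the large group with its six-membered ring and two sulfur atoms is not the only change here that ends at the limit, and even the exchange of one small group for another is enough to reach it. The step between compound 2 and compound 3 cannot be read, and the two groups cannot be ranked against each other, because both compounds end at the same limit: the limit of > 50000 nM in this assay, at which 2 of the 3 values shown sit.

On these data alone, how far beyond the limit compound 2 and compound 3 truly lie remains open. Also open is whether an ethyl group or an amine on this carbon would stay near compound 1 or would likewise end at the limit, so the compounds shown do not tell how narrowly the methyl group is tied to the value of compound 1.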